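The compounds below may be only part of what the source reports. "The series", "measured", "known", "first", "only" and "open" are said of these compounds alone.

Measured so far:
- compound 1, `CCCOC(=O)Nc1ccc([Se]C#N)cc1`: 9100 nM
- compound 2, `CCOC(=O)Nc1ccc([Se][Se]c2ccc(NC(=O)OCC)cc2)cc1`: 16700 nM

In an ADME assay on 184B5 cells (Homo sapiens) for cytotoxicity, read by MTT assay, with a stated time of 72 h (a higher number here means a weaker inhibitor of growth, a lower number a stronger inhibitor of growth), compound 1 gives 9100 nM. Of the two numbers available this is the smaller, but compound 2, a dimer joined through two selenium atoms and carrying ethyl carbamate groups, gives 16700 nM, and the gap between the two lies within the usual scatter of repeated measurements, so they cannot be told apart on these data.

Compound 3 `CCCCCCOC(=O)Nc1ccc([Se]C#N)cc1` has not yet been measured. It differs from compound 1 in one place: propyl in place of hydrogen on a saturated chain carbon, three bonds along the chain from an oxygen next to a carbonyl group. For the measured compounds named here, no pair of measured compounds shows a step of this kind, so the size and direction of the effect are open. The expectation is therefore a step in this assay no larger than the scatter, with the direction uncertain, as given by a 1.2-fold lower number from compound 1 to compound 3 (0.08 log units; within the scatter). On that basis compound 3 is estimated at 7500 nM, with a range from 2500 nM to 22000 nM.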

Compound 3, concentration for total growth inhibition: 20000 nM
Estimate against measurement, compound 3: 2.7-fold (0.43 log units) below; the range from low to high includes it.
By their numbers in this assay, from the lowest: compounds 1, 2 and 3 (each within the scatter of the next, the first and the last beyond it).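

At this place the chain is not a neutral spot: in this assay, going from propyl to hexyl gives a 2.2-fold higher number from compound 1 to compound 3 (0.34 log units; beyond the scatter), a modest step towards weaker inhibition of growth. The change adds only carbon, on a saturated chain carbon three bonds along the chain from an oxygen next to a carbonyl group, so this one pair shows that chain length alone can shift the read-out beyond the usual scatter. No measurement shown here accounts for the shift.

As far as these compounds go, a single step gives two chain lengths only, so it remains open whether the number climbs steadily through butyl and pentyl or jumps at one length. From the compounds shown here alone, how a longer chain, or an amine or a carboxylic acid at this place, would behave also remains open.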